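Methylphenyl isomers on the ring nitrogen: cytotoxicity notes

A few compounds are considered here, and "the series" means these few. Any claim that something is new, unique, unknown or untested is made for them only; others in the source may bear on it.

Measured so far in a functional assay on NCI-H460 cells (Homo sapiens) for cytotoxicity, read by MTT assay; a lower number here means a stronger inhibitor, a higher number a weaker inhibitor:
compound 1, `COc1cc(/C=C/C(=O)c2sc(Nc3ccc(C)cc3)nc2C)cc(OC)c1OC`: > 25000 nM, a limit of the assay.
compound 2, `COc1cc(/C=C/C(=O)c2sc(Nc3ccccc3C)nc2C)cc(OC)c1OC`: 6320 nM.
compound 3, `Cc1ccc(Nc2nc(C)c(C(=O)/C=C/c3ccccc3Cl)s2)cc1`: > 25000 nM, a limit of the assay.

Compound 1 and compound 2 share one core; compound 3 has another, and the difference between the two cores is not broken down here. From compound 1 to compound 2 the change is 2-methylphenyl in place of 4-methylphenyl on a nitrogen on an aromatic ring, giving an at least 3.9-fold lower number from compound 1 to compound 2 (0.59 log units; beyond the scatter) in this assay. Compound 4, `Cc1ccccc1Nc1nc(C)c(C(=O)/C=C/c2ccccc2Cl)s1`, is not yet measured; it stands to compound 3 as compound 2 stands to compound 1, the change being (2-methylphenyl in place of 4-methylphenyl on a nitrogen on an aromatic ring), the same change at the same place. Compound 3 gives only a limit, so its starting point is open; the limit of > 25000 nM in this assay, at which 2 of the 3 values shown sit, also leaves the measured step known only as a minimum. The expected step is an at least 1.6-fold lower number from compound 3 to compound 4 (0.22 log units; that floor lies within the scatter), resting on an at least 3.9-fold lower number from compound 1 to compound 2 (0.59 log units; beyond the scatter). Compound 4 is expected at 15000 nM, with a wide range and a fair chance that only a limit is reported.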

Compound 4, half-maximal inhibitory concentration: > 25000 nM
Compound 4 ended at the assay's limit (the forecaster's own chance of this, stated with the estimate: 45%); middle value at least 1.6-fold (0.22 log units) away from the limit.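

No step can be read from compound 3 to compound 4, since both compounds sit at a limit of the assay: the limit of > 25000 nM in this assay, at which 3 of the 4 values shown sit.

On these data alone, whether 2-methylphenyl in place of 4-methylphenyl lowers the number on the core of compound 3, as it does on the core of compound 1, stays open.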